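From methoxy to trifluoromethoxy: compound 3 to compound 4

A few compounds are considered here, and "the series" means these few. Any claim that something is new, unique, unknown or untested is made for them only; others in the source may bear on it.

Of the compounds shown here, three sharing one core have been measured in an ADME assay on the whole organism (strain Sprague-Dawley) for pharmacokinetics, with Rattus norvegicus as the target, using cassette dosing; a higher number here means faster removal of the compound, a lower number slower removal. Compound 1 `O=C(C[C@]1(O)CC[C@@H](Cc2ccccc2)CC1)Nc1ccc2[nH]c(=O)oc2c1` gives 34.1 mL/min/kg, compound 2 `O=C(C[C@]1(O)CC[C@@H](Cc2ccc(F)cc2)CC1)Nc1ccc2[nH]c(=O)oc2c1` gives 36.8 mL/min/kg and compound 3 `COc1ccc(C[C@H]2CC[C@](O)(CC(=O)Nc3ccc4[nH]c(=O)oc4c3)CC2)cc1` gives 45.9 mL/min/kg. Compound 3 therefore stands level with the other two, as its number lies within the scatter of both.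

Compound 4 `O=C(C[C@]1(O)CC[C@@H](Cc2ccc(OC(F)(F)F)cc2)CC1)Nc1ccc2[nH]c(=O)oc2c1` is reached from compound 3 by a single change: trifluoromethyl in place of methyl on an oxygen on an aromatic ring. In words, trifluoromethyl takes the place of methyl on an oxygen on an aromatic ring, turning 4-methoxyphenyl into 4-(trifluoromethoxy)phenyl.

Going by the values given here, no measured pair makes this exact change, so the evidence is indirect. The nearest guides are the steps at the same aromatic group: a 1.1-fold higher number from compound 1 to compound 2 (0.03 log units; within the scatter), a 1.3-fold higher number from compound 1 to compound 3 (0.13 log units; within the scatter) and a 1.2-fold higher number from compound 2 to compound 3 (0.10 log units; within the scatter). All three are small, and none leaves the scatter. On these three compounds, swapping the group has so far made no clear difference in this assay, although three compounds are a narrow base.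

No step beyond the scatter is therefore expected, and the expected step is a 1.2-fold lower number from compound 3 to compound 4 (0.09 log units; within the scatter). For compound 4 the estimated value is 37 mL/min/kg, with an expected range of 22 mL/min/kg to 60 mL/min/kg.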

Compound 4, clearance: 21 mL/min/kg
Estimate against measurement, compound 4: 1.8-fold (0.25 log units) above, outside the stated range (below it).
By their numbers in this assay, from the lowest: compounds 4, 1, 2 and 3 (each within the scatter of the next, the first and the last beyond it).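

In this assay, trifluoromethyl in place of methyl on an oxygen on an aromatic ring gives a 2.2-fold lower number from compound 3 to compound 4 (0.34 log units; beyond the scatter) and is the first step among these compounds to pass the scatter, although only modestly. Going by these compounds alone, the other two steps, a 1.8-fold lower number from compound 2 to compound 4 (0.24 log units; within the scatter) and a 1.6-fold lower number from compound 1 to compound 4 (0.21 log units; within the scatter), both remain within the scatter, so compound 4 stands apart only from compound 3, and the change at this position is clearly seen only in the exchange of 4-methoxyphenyl for 4-(trifluoromethoxy)phenyl. The data shown offer no measurement that would explain this step.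

The compounds shown leave open how this position would respond to an amine, a carboxylic acid or a nitrile, or to a longer chain such as ethyl on the same oxygen. They also leave open whether trifluoromethyl in place of methyl on this oxygen would give a step of similar size in this assay if another part of the shared core were altered, as the exchange is seen here in a single pair.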